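Compound 3 and the longer chain: LNCaP working notes

The compounds below may be only part of what the source reports. "The series", "measured", "known", "first", "only" and "open" are said of these compounds alone.

compound 1 `O=c1[nH]c(=O)n([C@@H]2C=C[C@@H](CO)O2)cc1F` | 85800 nM
compound 2 `CCCC(=O)OC[C@@H]1C=C[C@H](n2cc(F)c(N)nc2=O)O1` | > 100000 nM (a limit)

The read-out throughout is a functional assay on LNCaP cells (Homo sapiens) for antiproliferative activity; on this read-out lower numbers stand for stronger inhibition and higher numbers for weaker inhibition. In this assay compound 1 gives 85800 nM as a number. Compound 2 stands at > 100000 nM, which is a limit of the assay and not a number. The next compound to be read is compound 3 `CCCCC(=O)OC[C@@H]1C=C[C@H](n2cc(F)c(N)nc2=O)O1`. Its difference from compound 2 is methyl in place of hydrogen on a saturated chain carbon, three bonds along the chain from a carbonyl carbon, so that propyl becomes butyl. Within the data shown here, no measured step in this small set shows what such a change does, so the expectation rests on the size of the change alone. No step beyond the scatter is expected in this assay, and no direction is favoured. The estimated a number no higher from compound 2 to compound 3 (the limit leaves the size open) is therefore expected to be small. Since compound 2 gives > 100000 nM, another limit is the likelier report for the next reading. If a number is obtained, the expected value for compound 3 is 100000 nM, with an estimated range of 50000 nM to 200000 nM.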

Compound 3, half-maximal inhibitory concentration: > 100000 nM
Compound 3: only a limit was reported (the forecaster's own chance of this, stated with the estimate: 70%); the middle value lies on the limit itself.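

No step can be read from compound 2 to compound 3 in this assay, since each compound is reported only as a limit of the assay and not as a number: the limit of > 100000 nM in this assay, at which 2 of the 3 values shown sit.

The compounds shown leave open whether going from propyl to butyl changes antiproliferative activity at all, and in which direction.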